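A few compounds are considered here, and "the series" means these few. Any claim that something is new, unique, unknown or untested is made for them only; others in the source may bear on it.

Compound 1 `CN(C)CCn1cnnc1-c1cc(Oc2ccc(NC(=O)N/N=C/c3cc(C(C)(C)C)cc(C(C)(C)C)c3O)cc2F)ccn1` and compound 3 `CN(C)CCn1cnnc1-c1cc(Oc2ccc(NC(=O)N/N=C/c3ccc(O)c(Br)c3)cc2F)ccn1` share one core and differ only in the groups on the phenol ring. In an ADME assay on WI-38 cells (Homo sapiens) for cytotoxicity, read by MTT assay, with a stated time of 72 h (on this read-out lower numbers stand for stronger inhibition and higher numbers for weaker inhibition), compound 1 gives 2350 nM, and compound 3 gives 5560 nM, the higher of the two numbers that were obtained; compound 2 `CN(C)CCn1cnnc1-c1cc(Oc2ccc(NC(=O)N/N=C/c3cc(Br)c(O)c(Br)c3)cc2F)ccn1` stands in this assay as "not determined" (no result reported), with no result reported. Compound 4 `COc1cc(/C=N/NC(=O)Nc2ccc(Oc3ccnc(-c4nncn4CCN(C)C)c3)c(F)c2)ccc1O` has not yet been measured. The change from compound 3 to compound 4 is methoxy in place of bromo on an aromatic carbon. Without a measured step of the same kind to draw on, only a small step is expected in this assay, toward a somewhat higher number, and it may well stay within the scatter. Compound 4 is therefore estimated at 7000 nM, between 3000 nM and 16000 nM, an expected step of a 1.3-fold higher number from compound 3 to compound 4 (0.10 log units; within the scatter).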

Compound 4, half-maximal inhibitory concentration: 5320 nM
Compound 4: middle estimate off by 1.3-fold (0.12 log units), on the high side; the measured number falls inside the stated range.
By their numbers in this assay, from the lowest: compound 1; then compounds 4 and 3 (each within the scatter of the next).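

In this assay, putting methoxy in place of bromo on the aromatic carbon ortho to a hydroxy group gives a 1.0-fold lower number from compound 3 to compound 4 (0.02 log units; within the scatter), so the two compounds cannot be told apart by this read-out. For the compounds shown here, this is the first measured step at this position, and it shows that here a 3-bromo-4-hydroxyphenyl and a 4-hydroxy-3-methoxyphenyl group read alike. Nothing available explains this likeness. As far as these compounds go, whether an amine, a carboxylic acid or a longer chain such as ethoxy at this position would also read alike remains open.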